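This account rests on a few compounds, and the source may have more. Where it says the series, first, only, none or still open, it means among the compounds named here.

Working notes on the series. Compound 1 `COc1cc(-c2cc(/C=C/C(=O)c3ccc(N)cc3)[nH]n2)cc(OC)c1OC` gives 8170 nM in a functional assay on M14 cells (Homo sapiens) for inhibition, read by sulforhodamine B assay, with a stated time of 48 h; a lower number here means that less compound is tolerated, a higher number that more compound is tolerated. Compound 3 `COc1ccc(C(=O)/C=C/c2cc(-c3cc(OC)c(OC)c(OC)c3)n[nH]2)cc1OC` gives 7380 nM in this assay, and the step of a 1.1-fold lower number from compound 1 to compound 3 (0.04 log units; within the scatter) lies within the scatter. Compound 2 `COc1cc(-c2cc(/C=C/C(=O)c3ccc(Cl)c(Cl)c3)[nH]n2)cc(OC)c1OC` reaches only a limit in this assay, > 100000 nM; this is the limit described as the limit of > 100000 nM in this assay, at which 1 of the 3 values shown sits. The steps of an at least 12-fold higher number from compound 1 to compound 2 (1.08 log units; beyond the scatter) and an at least 13-fold lower number from compound 2 to compound 3 (1.13 log units; beyond the scatter) are both large. Among the numbers shown, compound 3 stands lowest, with compound 1 nearest and within the scatter of it.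

Compound 4 `COc1ccc(C(=O)/C=C/c2cc(-c3cc(OC)c(OC)c(OC)c3)n[nH]2)cc1` is to be measured in this assay. It differs from compound 3 as follows: hydrogen in place of methoxy on an aromatic carbon. Going by the values given here, none of the measured steps removes a single methoxy group; each replaces the whole aryl group on the carbonyl carbon, so no measured step bears directly on this change. The nearest guide is that compound 1 and compound 3, carrying different groups on that carbonyl carbon, sit within the scatter of each other. For compound 4 a step of a 1.2-fold higher number from compound 3 to compound 4 (0.09 log units; within the scatter) within the scatter is therefore expected. Compound 4 is estimated at 9000 nM, with a range from 3000 nM to 30000 nM.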

Compound 4, concentration lethal to 50% of the cells: > 100000 nM
Compound 4: a limit, no number (the forecaster's own chance of this, stated with the estimate: 10%); at least 11-fold (1.04 log units) between middle value and limit.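

Taking away one methoxy group, ortho to a methoxy group, is enough for a large step in this assay: an at least 13-fold higher number from compound 3 to compound 4 (1.13 log units; beyond the scatter). The earlier compounds shown here showed large steps only when the whole aryl group on the carbonyl carbon was replaced, and compound 1 and compound 3 stayed within the scatter of each other, whereas the 4-methoxyphenyl group of compound 4 now stands apart from the 4-aminophenyl group, with an at least 12-fold higher number from compound 1 to compound 4 (1.08 log units; beyond the scatter). Compound 4 gives only a limit, not a number, as compound 2 does, so the step between these two cannot be read: the limit of > 100000 nM in this assay, at which 2 of the 4 values shown sit.

The compounds shown leave open whether this position needs a methoxy group specifically, or whether a hydroxyl group, a fluorine atom or an ethoxy group there would serve as well. They also leave open whether an amine at this position would behave like the methoxy group of compound 3.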